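Swapping a Chloropyridyl for a Chlorofluorophenyl Group

The source may hold more compounds than are shown below. What is called first, only, known or untested is meant among the compounds shown, and "the series" means these compounds.

Compound 1 `CCn1cccc(-c2ccc(N3C[C@H](CNC(=O)c4ccc(Cl)s4)OC3=O)cc2OC)c1=O` and compound 2 `COc1cc(C(=O)N2CCC(O)C(C)C2)cc2nc(NCc3cncc(Cl)c3)oc12` were both tested in an assay on isolated protein for inhibition of thyroid hormone receptor beta (Homo sapiens), read by fluorescence, with a stated time of 30 min; a higher number here means a weaker inhibitor, a lower number a stronger inhibitor. Compound 1 gives 61 nM, while compound 2 gives 7200 nM, the higher of the two numbers and beyond the scatter from compound 1. Compound 3 `COc1cc(C(=O)N2CCC(O)C(C)C2)cc2nc(NCc3cc(Cl)ccc3F)oc12` differs from compound 2 by 5-chloro-2-fluorophenyl in place of 5-chloropyridin-3-yl on a saturated chain carbon bound to a nitrogen on an aromatic ring, on a saturated chain carbon bound to a nitrogen on an aromatic ring. Among the measured compounds shown here, no measured pair shows this change, so the expected step of a 1.4-fold lower number from compound 2 to compound 3 (0.16 log units; within the scatter) is small, in either direction or none beyond the scatter. Compound 3 is therefore estimated at 5000 nM, within 1500 nM to 20000 nM.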

Compound 3, half-maximal inhibitory concentration: 300 nM
Compound 3: the middle estimate sits 17-fold (1.22 log units) above what was measured; the measured number lies below the stated range.
By their numbers in this assay, from the lowest: compound 1; then compound 3; then compound 2.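

In this assay the swap of 5-chloropyridin-3-yl for 5-chloro-2-fluorophenyl, on a saturated chain carbon bound to a nitrogen on an aromatic ring, gives a 24-fold lower number from compound 2 to compound 3 (1.38 log units; beyond the scatter) and so shows that the number is sensitive to the group at this position. The change replaces a ring with a hetero atom by one of carbon only and also brings in a fluorine, and this single step cannot separate those two differences. No measurement given here accounts for the size of the step.

On these data alone, whether plain phenyl would stand nearer compound 2 or compound 3 remains open. So does the effect of a methoxy group or a nitrile in place of the chlorine.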